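Aryl swap on the benzyl-bearing core: compound 3 to compound 4

The source may hold more compounds than are shown below. What is called first, only, known or untested is meant among the compounds shown, and "the series" means these compounds.

Measured so far:
compound 1 `COc1ccccc1-c1cn2ccnc2c(-c2ccc3ncn(C4CCCCC4)c3c2)n1` — 2.79%
compound 2 `c1csc(-c2cn3ccnc3c(-c3ccc4ncn(C5CCCCC5)c4c3)n2)c1` — 5.95%
compound 3 `CCc1ccc(-c2cn3ccnc3c(-c3ccc4ncn(Cc5ccccc5)c4c3)n2)cc1` — 23%

In a functional assay on NCI-H23 cells (Homo sapiens) for inhibition, read by sulforhodamine B assay, with a stated time of 48 h, tested at 10 uM (a lower number here means less inhibition, a higher number more inhibition at the concentration tested (going by the name of the read-out)), compound 3 stands highest of the three, beyond the scatter from both compound 2 and compound 1. Compound 4 `Cc1cccc(-c2cn3ccnc3c(-c3ccc4ncn(Cc5ccccc5)c4c3)n2)c1` differs from compound 3 in one place: 3-methylphenyl in place of 4-ethylphenyl on an aromatic carbon. Among the measured compounds shown here, the only measured step at that place is the aryl change a number 3.2 percentage points higher from compound 1 to compound 2 (within the scatter), which sits on the cyclohexyl-bearing core and stayed within the scatter. For the measured compounds named here, no step between two compounds of the benzyl-bearing core is known. On that precedent the step of a number 5 percentage points lower from compound 3 to compound 4 (within the scatter) is expected to be small, not beyond the scatter, with a slight lean downward allowed. Compound 4 is therefore estimated at 18%, within 5% to 33%.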

Compound 4, a percentage reported as inhibition, at one concentration (the size of the read-out at that concentration, not a potency): 9.09%
Compound 4: middle estimate off by 8.9 percentage points, on the high side; the range from low to high includes it.
By their numbers in this assay, from the lowest: compounds 1, 2 and 4 (each within the scatter of the next); then compound 3.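

On the benzyl-bearing core the aryl group at this position matters: in this assay the swap gives a number 13.9 percentage points lower from compound 3 to compound 4 (beyond the scatter), beyond the scatter, while a number 3.2 percentage points higher from compound 1 to compound 2 (within the scatter), on the cyclohexyl-bearing core, stayed within it. The change alters both the alkyl chain and its place on the phenyl ring, and these compounds cannot separate the two. Nothing measured here explains the step.

Open, as far as these compounds go, is how 3-ethylphenyl or 4-methylphenyl would stand on this core. Also open, from the compounds shown here alone, is whether an amine or a carboxylic acid on that phenyl ring would shift the inhibition.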